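The source may hold more compounds than are shown below. What is called first, only, known or untested is meant among the compounds shown, and "the series" means these compounds.

In a functional assay on HCT-116 cells (Homo sapiens) for cytotoxicity, read by scintillation counting and thymidine incorporation, with a stated time of 72 h (a lower number here means a stronger inhibitor, a higher number a weaker inhibitor), compound 1 (`C=C(c1cc(OC)cc(OC)c1)c1ccc(OC)c(OC)c1`) gives > 10000 nM, which is a limit of the assay and not a number. Compound 2 (`C=C(c1cc(OC)cc(OC)c1)c1ccc(OC)c(O)c1`), with hydrogen in place of methyl on an oxygen on an aromatic ring, gives 21 nM. For the measured compounds named here, that swap is the only measured step, an at least 470-fold lower number from compound 1 to compound 2 (2.67 log units; beyond the scatter), and it is large. It shows that the shared core can inhibit strongly, but it says nothing directly about the new change. Compound 3 (`COC=C(c1cc(OC)cc(OC)c1)c1ccc(OC)c(OC)c1`) keeps that methyl and differs from compound 1 elsewhere: methoxy in place of hydrogen on a double-bonded chain carbon bound to a double-bonded chain carbon. Going by the values given here, no measured step covers methoxy in place of hydrogen on a double-bonded chain carbon, so compound 3 is expected to remain weak, probably again reported only as a limit. The expected change is small, a number no higher from compound 1 to compound 3 (the limit leaves the size open). For compound 3 the estimate is 10000 nM, with an expected range from 1000 nM to 30000 nM.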

Compound 3, half-maximal inhibitory concentration: > 10000 nM
Compound 3: a limit, no number; the forecaster's own chance of this, stated with the estimate: 65%; the middle value sits exactly at the limit.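

For the compounds shown here, both compound 1 and compound 3 stop at the same assay limit, so no step between them can be read: the limit of > 10000 nM in this assay, at which 2 of the 3 values shown sit. The compounds shown leave open whether methoxy in place of hydrogen on a double-bonded chain carbon changes the number at all, on this core or on compound 2.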